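Aryl halogen pattern on the shared core

This account rests on a few compounds, and the source may have more. Where it says the series, first, only, none or still open, it means among the compounds named here.

Among the compounds with values here, compound 1 `CC(=O)Nc1cccc(C2CCN(CCCn3c(-c4ccccc4Cl)nc4ccccc43)CC2)c1` gives 10 nM in an assay for displacement of a labelled ligand from melanin-concentrating hormone receptor 1 (Homo sapiens), read by fluorescence (on this read-out higher numbers stand for weaker inhibition and lower numbers for stronger inhibition), the lower of the two numbers measured so far. Compound 2 `CC(=O)Nc1cccc(C2CCN(CCCn3c(-c4ccc(C#N)cc4)nc4ccccc43)CC2)c1` gives 16 nM in this assay. Within the data shown here, the only measured step, a 1.6-fold higher number from compound 1 to compound 2 (0.20 log units; within the scatter), therefore tells of little movement when the aryl group on the shared core is exchanged. Compound 3 `CC(=O)Nc1cccc(C2CCN(CCCn3c(-c4ccc(Cl)cc4F)nc4ccccc43)CC2)c1` differs from compound 1 by 4-chloro-2-fluorophenyl in place of 2-chlorophenyl on an aromatic carbon. Among the measured compounds shown here, no measured step covers this exact exchange, and the one aryl change seen stayed within the scatter, so no step beyond the scatter is expected, direction uncertain. Compound 3 is estimated at 15 nM, between 5 nM and 45 nM, an expected step of a 1.5-fold higher number from compound 1 to compound 3 (0.18 log units; within the scatter).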

Compound 3, half-maximal inhibitory concentration: 1 nM
Beside the measured number, compound 3's estimate is 15-fold (1.18 log units) above it; the whole stated range lies above it.
By their numbers in this assay, from the lowest: compound 3; then compounds 1 and 2 (each within the scatter of the next).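

At this aromatic carbon between two ring nitrogen atoms, the aryl group can move the number in this assay well beyond the scatter: 4-chloro-2-fluorophenyl gives a 10-fold lower number from compound 1 to compound 3 (1.00 log units; beyond the scatter) and a 16-fold lower number from compound 2 to compound 3 (1.20 log units; beyond the scatter). The exchange between compound 1 and compound 2 had not shown this sensitivity. No evidence on the origin of this step is at hand.

Still open, on these data alone, is how 4-chlorophenyl or 2-fluorophenyl alone would read here, which would separate the contributions of the two halogens. Also open, as far as these compounds go, is whether an amine or a carboxylic acid on this aryl ring would be tolerated.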